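The compounds below may be only part of what the source reports. "The series", "measured", "known", "first", "only" and "open" are said of these compounds alone.

Going by the values given here, compound 1 `O=C(Nc1cccc(C(F)(F)F)c1)Nc1nnc(Sc2ncnc3scc(-c4ccncc4)c23)s1` is tested in a functional assay on T47D cells (Homo sapiens) for antiproliferative activity, read by MTT assay, with a stated time of 48 h (on this read-out lower numbers stand for stronger inhibition and higher numbers for weaker inhibition), where compound 1 gives 45100 nM, the highest of the two numbers measured so far. Its closest neighbour is compound 2 `Cc1ccc(NC(=O)Nc2nnc(Sc3ncnc4scc(-c5ccncc5)c34)s2)cc1Cl`, which in this assay gives 34800 nM; the step is a 1.3-fold lower number from compound 1 to compound 2 (0.11 log units; within the scatter). Among the compounds with values here, compound 3 `O=C(Nc1ccc(Cl)cc1)Nc1nnc(Sc2ncnc3scc(-c4ccncc4)c23)s1` differs from compound 1 by 4-chlorophenyl in place of 3-(trifluoromethyl)phenyl on an amide-type nitrogen, a swap of one aromatic group on the urea part, like the single measured step. Because that step was a 1.3-fold lower number from compound 1 to compound 2 (0.11 log units; within the scatter), the change to compound 3 is expected to give a step of a 1.1-fold lower number from compound 1 to compound 3 (0.05 log units; within the scatter), none beyond the scatter. Compound 3 is therefore estimated at 40000 nM, between 15000 nM and 100000 nM.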

Compound 3, half-maximal inhibitory concentration: 23300 nM
Compound 3: middle estimate off by 1.7-fold (0.23 log units), on the high side, and the stated range covers the measured number.
By their numbers in this assay, from the lowest: compounds 3, 2 and 1 (each within the scatter of the next).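

Placing 4-chlorophenyl on the amide-type nitrogen gives a 1.9-fold lower number from compound 1 to compound 3 (0.29 log units; within the scatter) and a 1.5-fold lower number from compound 2 to compound 3 (0.17 log units; within the scatter), so both steps stay within the scatter. Three different aromatic groups now sit at this position without a clear separation, even though 4-chlorophenyl has fewer heavy atoms than 3-(trifluoromethyl)phenyl. No outside evidence bears on this result.

From the compounds shown here alone, it remains open whether a carboxylic acid or an amine on this aromatic ring would move the number beyond the scatter. The same question stands for a longer alkyl chain in place of the ring.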